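Swapping bromo for iodo on a growth inhibitor

The source may report more compounds than this note shows. Statements on the series, on what has been measured and on what is new or still open speak of the compounds shown alone.

Among the measured compounds shown here, in a functional assay on OVCAR-3 cells (Homo sapiens) for inhibition, read by sulforhodamine B assay, with a stated time of 48 h (a higher number here means a weaker inhibitor of growth, a lower number a stronger inhibitor of growth), compound 1 `Cc1ccc(NC(=O)/C=C/c2ccccc2)c(C(N)=O)c1` gives 2180 nM as its value, while compound 2 `NC(=O)c1cc(Br)ccc1NC(=O)/C=C/c1ccccc1` gives 349 nM as its value, the lower of the two numbers so far. Compound 3 `NC(=O)c1cc(I)ccc1NC(=O)/C=C/c1ccccc1` keeps the shared core and makes one change: iodo in place of bromo on an aromatic carbon with iodo in place of bromo on an aromatic carbon, meta to a carbamoyl group. For the measured compounds named here, the only measured step bearing on this is a 6.2-fold lower number from compound 1 to compound 2 (0.80 log units; beyond the scatter) with bromo in place of methyl, and it lies beyond the scatter. Going by the values given here, it replaced methyl, however, and no measurement yet shows what replacing bromo does. The expected change in this assay is therefore small, a 1.2-fold lower number from compound 2 to compound 3 (0.10 log units; within the scatter) and within the scatter. Compound 3 is expected near 280 nM with an estimated range from 110 nM to 700 nM in this measurement.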

Compound 3, concentration for 50% growth inhibition: 353 nM
Beside the measured number, compound 3's estimate is 1.3-fold (0.10 log units) below it; the range from low to high includes it.
By their numbers in this assay, from the lowest: compounds 2 and 3 (each within the scatter of the next); then compound 1.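

In this assay, iodo in place of bromo gives a 1.0-fold higher number from compound 2 to compound 3 (0.00 log units; within the scatter) at this position, meta to a carbamoyl group, so the two groups cannot be told apart here. Iodo in place of methyl gives a 6.2-fold lower number from compound 1 to compound 3 (0.79 log units; beyond the scatter) and so the lower number first seen with bromo is not confined to bromo: two different groups at this carbon now both stand clearly below methyl. No supporting information is available to explain why bromo and iodo give matching numbers here.

The compounds shown leave open whether this lower number extends to other groups at the same carbon, such as chloro, fluoro, an amine or a carboxylic acid. They also leave open whether the match between bromo and iodo would hold in other cell lines.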